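Series notes: the step from compound 1 to compound 4

The source may hold more compounds than are shown below. What is called first, only, known or untested is meant among the compounds shown, and "the series" means these compounds.

Measured in a functional assay on CHO cells for agonist activity at Free fatty acid receptor 1 (Homo sapiens), read by a luciferase reporter; a lower number here means a smaller maximal response, a higher number a larger maximal response:
compound 1 `Cc1nc(-c2ccc(C(F)(F)F)cc2)sc1CNc1ccc(CCC(=O)O)cc1` gives 108%
compound 2 `O=C(O)/C=C/c1ccc(NCc2cccc(Oc3ccccc3)c2)cc1` gives 76%
compound 3 `CN(C)C(=O)CCc1ccc(NCc2cccc(Oc3ccccc3)c2)cc1` gives 50%

Compound 1 holds the highest maximal response of the three, beyond the scatter above both compound 2 and compound 3. Compound 4 `Cc1nc(-c2ccc(C(F)(F)F)cc2)sc1CNc1ccc([C@H]2C[C@@H]2C(=O)NC2CCNC2)cc1` keeps the core of compound 1 and differs in one place, para to a large group: 2-((pyrrolidin-3-yl)carbamoyl)cyclopropyl in place of 2-carboxyethyl on an aromatic carbon. For the measured compounds named here, the only measured step that bears on this is a number 26 percentage points lower from compound 2 to compound 3 (beyond the scatter), where 2-(dimethylcarbamoyl)ethyl took the place of 2-carboxyethenyl; the drop was modest but beyond the scatter. Both steps swap a carboxy-bearing group for a carbamoyl-bearing one, so a lowering beyond the scatter is expected for compound 4, roughly a number 36 percentage points lower from compound 1 to compound 4 (beyond the scatter). The estimate for compound 4 in this assay is 72%, within 40% to 100%.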

Compound 4, largest response reached (reported as percent of maximum), in percent of the reference or control that the assay uses: 52%
Compound 4: the middle estimate sits 20 percentage points above what was measured, and the stated range covers the measured number.
By their numbers in this assay, from the lowest: compounds 3 and 4 (each within the scatter of the next); then compound 2; then compound 1.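

In this assay, 2-((pyrrolidin-3-yl)carbamoyl)cyclopropyl in place of 2-carboxyethyl gives a number 56 percentage points lower from compound 1 to compound 4 (beyond the scatter) and so shows a large loss of maximal response at this position on the core of compound 1. Compound 4 still gives 52% here, so the carboxy-free group lowers the response without removing it. Nothing available gives a reason for this drop.

The change alters the linker and the end group together, so which part accounts for the drop stays open. A carboxylic acid on the cyclopropyl group of this core would separate the two.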